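The source may report more compounds than this note shows. Statements on the series, on what has been measured and on what is new or still open speak of the compounds shown alone.

Measured so far in an assay on HEK293 cells for positive allosteric modulation of metabotropic glutamate receptor 3 (Rattus norvegicus), read by thallium flux, with a stated time of 2.5 min; a lower number here means a smaller maximal response, a higher number a larger maximal response:
compound 1, `CCC(=O)c1ccc(OCCCCOc2cc(C(=O)O)ccc2OC)c(C)c1O`: 62.5%
compound 2, `CCCC(=O)c1ccc(OCCCCOc2cc(C(=O)O)ccc2OC)c(C)c1O`: 64.2%

Compound 2 stands highest of the two numbers, though the step of a number 1.7 percentage points higher from compound 1 to compound 2 (within the scatter) lies within the scatter, so the two are not separated. Compound 3, `COc1ccc(C(=O)O)cc1OCCCCOc1ccc(C(=O)C(C)C)c(O)c1C`, differs from compound 2 by isopropyl in place of propyl on a carbonyl carbon. Within the data shown here, the only measured step, a number 1.7 percentage points higher from compound 1 to compound 2 (within the scatter), changes the same alkyl chain in length and did not move the read-out; no step beyond the scatter is expected here either. For compound 3 the expected step is a number 0.2 percentage points lower from compound 2 to compound 3 (within the scatter), giving an estimate of 64% with a range of 54% to 74%.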

Compound 3, largest response reached (reported as percent of maximum), in percent of the reference or control that the assay uses: 59.9%
The estimate for compound 3 lay 4.1 percentage points above the measured number; measured number inside the range.
By their numbers in this assay, from the lowest: compounds 3, 1 and 2 (each within the scatter of the next).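

Branching is accepted at this position in this assay: isopropyl in place of propyl on a carbonyl carbon gives a number 4.3 percentage points lower from compound 2 to compound 3 (within the scatter), and methyl in place of hydrogen on the saturated chain carbon bound to the carbonyl carbon gives a number 2.6 percentage points lower from compound 1 to compound 3 (within the scatter) in the same series. The branched chain of compound 3 is therefore not separated from either unbranched chain by this read-out. No supporting data bear on a cause for this result.

Still open, going by these compounds, is how a longer chain, a cyclopropyl group or an amine-bearing chain on the carbonyl carbon would read. Whether any group at this position gives a step beyond the scatter also remains unsettled.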